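This account rests on a few compounds, and the source may have more. Where it says the series, first, only, none or still open, it means among the compounds named here.

Measured in a functional assay on HT-29 cells (Homo sapiens) for inhibition, read by luminescence and CellTiter-Glo, with a stated time of 24 h; on this read-out higher numbers stand for an effect only at larger amounts of compound and lower numbers for an effect already at smaller amounts:
Compound 1 `CC(C)n1nc(C(=O)N[C@H]2COc3ccccc3N(C)C2=S)nc1Cc1ccccc1` gives 360 nM
Compound 2 `CN1C(=S)[C@@H](NC(=O)c2nc(Cc3ccccc3)n(CCCO)n2)COc2ccccc21` gives 209 nM
Compound 3 `CN1C(=S)[C@@H](NC(=O)c2nc(Cc3ccccc3)n(C3CCOC3)n2)COc2ccccc21` gives 1580 nM

Compound 3 at 1580 nM stands highest of the three, so it needs the most compound for its effect. Among the measured compounds shown here, compound 4 `CN1C(=S)[C@@H](NC(=O)c2nc(Cc3ccccc3)n(CC3CCOCC3)n2)COc2ccccc21` keeps the shared core and carries (oxan-4-yl)methyl in place of oxolan-3-yl on an aromatic nitrogen as its one change.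

All three measured steps concern this same nitrogen. Going from isopropyl to 3-hydroxypropyl gives a 1.7-fold lower number from compound 1 to compound 2 (0.24 log units; within the scatter) and so separates those two groups by no real margin. Oxolan-3-yl gives a 4.4-fold higher number from compound 1 to compound 3 (0.64 log units; beyond the scatter) and also a 7.6-fold higher number from compound 2 to compound 3 (0.88 log units; beyond the scatter) in the same direction. For the measured compounds named here, no measured compound carries (oxan-4-yl)methyl, so these steps are only a loose guide.

Going by the values given here, with compound 1 at 360 nM and compound 2 at 209 nM as the only other groups here, a move back toward lower numbers is expected. The expected change in this assay is a 2.6-fold lower number from compound 3 to compound 4 (0.42 log units; beyond the scatter) and is of modest size. The estimate for compound 4 is 600 nM with an expected range of 170 nM to 2000 nM around it.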

Compound 4, half-maximal effective concentration: 6310 nM
Beside the measured number, compound 4's estimate is 11-fold (1.02 log units) below it, outside the stated range (above it).
By their numbers in this assay, from the lowest: compounds 2 and 1 (each within the scatter of the next); then compound 3; then compound 4.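

In this assay the aromatic nitrogen proves more sensitive to the group it carries than the first three compounds could show: (oxan-4-yl)methyl in place of oxolan-3-yl gives a 4.0-fold higher number from compound 3 to compound 4 (0.60 log units; beyond the scatter) and so moves further from the open-chain groups. The gap to those groups is wider still, with an 18-fold higher number from compound 1 to compound 4 (1.24 log units; beyond the scatter) and a 30-fold higher number from compound 2 to compound 4 (1.48 log units; beyond the scatter) as the two large steps of the series. Among these four compounds, both groups with an oxygen-containing ring therefore stand above both open-chain groups, and no compound goes against this. Nothing available here gives a reason for these steps.

As far as these compounds go, because the ring size and the added chain carbon change together between compound 3 and compound 4, their separate contributions stay open. Also open, from the compounds shown here alone, is whether an amine, a carboxylic acid or a longer hydroxyalkyl chain on this nitrogen would fall nearer compound 2 or compound 4.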